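Shortening the Alkyl Chain on a Shared Core

The source may hold more compounds than are shown below. What is called first, only, known or untested is meant among the compounds shown, and "the series" means these compounds.

Of the compounds shown here, three built on one shared core have been tested in a functional assay on HEL cells (Homo sapiens); a higher number here means that more compound is tolerated, a lower number that less compound is tolerated. Compound 1, `CCCCCCC#Cc1cc2cn(COCCO)c(=O)nc2o1`, gives only a limit in this assay, > 50000 nM, not a number. Compound 2, `CCCCCCCCCCCc1cc2cn(COCCO)c(=O)nc2o1`, gives 132000 nM in this assay. Compound 3, `CCCCCCCCCCCc1cc2cn(COCCO)c(O)nc-2n1`, gives 41000 nM in this assay. Of the two plain numbers, compound 2 stands highest, with compound 3 a good distance below it, beyond the usual scatter. Among the measured compounds shown here, for compound 1 the only information is the limit itself: the limit of > 50000 nM in this assay, at which 1 of the 3 values shown sits.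

The next compound, compound 4, `CCCCCc1cc2cn(COCCO)c(=O)nc2o1`, differs from compound 2 in one place: hydrogen in place of hexyl on a saturated chain carbon, five bonds along the chain from an aromatic carbon. For the measured compounds named here, no pair among the measured compounds isolates this change, so the direction of the step in this assay rests on judgement alone. The expected step of a 1.2-fold higher number from compound 2 to compound 4 (0.08 log units; within the scatter) is small, with the number staying about as high as that of compound 2 or drifting somewhat higher. Compound 4 is therefore expected to give about 160000 nM in this assay, somewhere between 60000 nM and 400000 nM.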

Compound 4, half-maximal cytotoxic concentration: > 200000 nM
Compound 4: a limit, no number; the forecaster's own chance of this, stated with the estimate: 40%; middle value at least 1.2-fold (0.09 log units) from the limit.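

Putting hydrogen in place of hexyl on this saturated chain carbon gives an at least 1.5-fold higher number from compound 2 to compound 4 (0.18 log units; that floor lies within the scatter) in this assay. Among the compounds shown here, compound 4 gives only a limit, not a number, so this step is a floor and not a measured size: the limit of > 200000 nM in this assay, at which 1 of the 4 values shown sits. This is the first comparison of two compounds that differ only in this part of the chain, and it shows that the much shorter chain of compound 4 brings no drop in the number, although the floor alone is too small to prove a real rise.

Going by these compounds, how far the true value of compound 4 lies past its limit remains open. Also open, on these data alone, is whether a longer chain, or an amine in place of the hexyl, would shift the number on this shared core.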